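Working notes: aryl swap from compound 1 to compound 4

The source may report more compounds than this note shows. Statements on the series, on what has been measured and on what is new or still open speak of the compounds shown alone.

Measured so far in an ADME assay on A549 cells (Homo sapiens) for cytotoxicity, read by MTT assay, with a stated time of 48 h; on this read-out lower numbers stand for stronger inhibition of growth and higher numbers for weaker inhibition of growth:
- compound 1 `O=C(/C=C\c1cccc([N+](=O)[O-])c1)N1N=C(c2ccncc2)OC1c1c[nH]c2ccccc12` gives > 30 ug/mL, which is a limit of the assay.
- compound 2 `O=C(/C=C\c1ccc(Cl)cc1)N1N=C(c2ccncc2)OC1c1c[nH]c2ccccc12` gives > 30 ug/mL, again a limit.
- compound 3 `O=C(/C=C/c1c(Cl)cccc1Cl)N1N=C(c2ccncc2)OC1c1c[nH]c2ccccc12` gives > 30 ug/mL, again a limit.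

Compound 1 therefore stands only at a limit in this assay; the two further values shown are limits as well, and all three sit at the same point (the limit of > 30 ug/mL in this assay, at which 3 of the 3 values shown sit). The step that the two limits leave unreadable from compound 1 to compound 2 cannot be read, nor can a step that the two limits leave unreadable from compound 1 to compound 3 or a step that the two limits leave unreadable from compound 2 to compound 3.

Compound 4 `O=C(/C=C\c1ccc(Br)cc1)N1N=C(c2ccncc2)OC1c1c[nH]c2ccccc12` is the next variant. Relative to compound 1 the change is 4-bromophenyl in place of 3-nitrophenyl on a double-bonded chain carbon bound to a double-bonded chain carbon. The step that bears on it most closely is a step that the two limits leave unreadable from compound 1 to compound 2, where 4-chlorophenyl replaced the same 3-nitrophenyl on the same double-bonded chain carbon and the value stayed at the limit; the other two steps are equally unreadable. Among the measured compounds shown here, no direction of change can be expected from these data, only that compound 4 is likely to sit at the limit too. In this assay the value of compound 4 is therefore estimated at 45 ug/mL, between 25 ug/mL and 120 ug/mL, with a limit the most likely outcome. The step this estimate means is a step that the limit leaves unreadable from compound 1 to compound 4, expected to remain unreadable against the limits.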

Compound 4, concentration for 50% growth inhibition: > 30 ug/mL
Compound 4: a limit, no number (the forecaster's own chance of this, stated with the estimate: 80%); the middle value is on the limit's open side.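

Compound 4 sits at a limit, as do compound 1, compound 2 and compound 3, so no step among these four compounds can be read in this assay: the limit of > 30 ug/mL in this assay, at which 4 of the 4 values shown sit.

The compounds shown leave open whether any aryl group on this ethenyl chain of the shared core gives a numerical value in this assay.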